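The compounds below may be only part of what the source reports. "The series", "measured", "known", "first", "only" and "open" are said of these compounds alone.

Compound 1 `Cc1ccc(NC2=CC(=O)c3nc4n(c3C2=O)[C@H]2OC[C@@H](O)[C@H]2OC4)cc1C` gives 2820 nM in a functional assay on ECa-109 cells for inhibition, with ECa-109 cell line (Homo sapiens) as the target, read by sulforhodamine B assay; on this read-out lower numbers stand for stronger inhibition and higher numbers for weaker inhibition.
Compound 2 `CCOc1ccc(NC2=CC(=O)c3c(nc4n3[C@H]3OC[C@@H](O)[C@H]3OC4)C2=O)cc1` reaches only a limit in this assay, > 4000 nM.
Compound 3 `O=C1C(NC2CCCCC2)=CC(=O)c2c1nc1n2[C@H]2OC[C@@H](O)[C@H]2OC1` likewise sits at a limit in this assay, > 16000 nM.

Among the compounds with values here, compound 1 thus holds the only real number among the three; the other two are limits. Within the data shown here, the single comparable step, a step that the two limits leave unreadable from compound 2 to compound 3, cannot be sized because the limit of > 4000 nM in this assay, at which 1 of the 3 values shown sits, and the limit of > 16000 nM in this assay, at which 1 of the 3 values shown sits, bound both of its ends. Compound 4 `O=C1C=C(N2CCCC2)C(=O)c2c1nc1n2[C@H]2OC[C@@H](O)[C@H]2OC1` differs from compound 1 by pyrrolidin-1-yl in place of (3,4-dimethylphenyl)amino on a double-bonded ring carbon. Among the measured compounds shown here, no measured step shows this change directly, so the expectation rests on compound 1 alone and on the two limits. A weakening step is expected, a 2.8-fold higher number from compound 1 to compound 4 (0.45 log units; beyond the scatter), though with wide uncertainty. Compound 4 is therefore estimated at 8000 nM, within 2500 nM to 30000 nM.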

Compound 4, half-maximal inhibitory concentration: > 16000 nM
Compound 4 gave a limit, no number; the forecaster's own chance of this, stated with the estimate: 45%; middle value at least 2.0-fold (0.30 log units) from the limit.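

Within the data shown here, the step of an at least 5.6-fold higher number from compound 1 to compound 4 (0.75 log units; beyond the scatter) is the first readable one at this position, and it shows that this swap costs clear activity. Compound 4 reads > 16000 nM in this assay and that is a limit, not a number, so the real loss could be larger. Among the compounds shown, only the aromatic (3,4-dimethylphenyl)amino group on this carbon gives a measured value.

On these data alone, the swap removes the aromatic ring and the hydrogen-bond donor together, so their separate shares stay unknown. An N-methyl-N-phenylamino group, which keeps the ring without the donor, could separate them.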